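The source may report more compounds than this note shows. Statements on the series, on what has been measured and on what is new or still open speak of the compounds shown alone.

Compound 1 `Cc1cccc(NC(=O)c2cccc(/C=C3\CC(=O)N(c4ccccc4)C3=O)c2)c1` was tested in an ADME assay on NCM460 cells (Homo sapiens) for cytotoxicity, read by MTT assay, with a stated time of 72 h; a lower number here means a stronger inhibitor, a higher number a weaker inhibitor. In this assay compound 1 gives > 100000 nM, which is a limit of the assay and not a number. Compound 2 `CCCCNC(=O)c1cccc(/C=C2\CC(=O)N(Cc3ccccc3)C2=O)c1` was examined in the same way. In this assay compound 2 gives > 100000 nM, again a limit rather than a number. Compound 1 thus stands at the limit of > 100000 nM in this assay, at which 2 of the 2 values shown sit, with no numeric value to place it against anything else, since both values shown are limits. Compound 3 `CSc1cccc(NC(=O)c2cccc(/C=C3\CC(=O)N(c4ccccc4)C3=O)c2)c1` has not yet been measured. It differs from compound 1 in one place: methylsulfanyl in place of methyl on an aromatic carbon, on an aromatic carbon of a six-membered aromatic ring of carbon only. For the measured compounds named here, with no measured step to draw on, no change beyond the usual scatter is expected in this assay from this exchange. Compound 3 is accordingly expected to give about 100000 nM, within 30000 nM to 300000 nM, most likely reported again only as a limit. The step this estimate implies, a number no higher from compound 1 to compound 3 (the limit leaves the size open), is expected to stay within the scatter.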

Compound 3, half-maximal inhibitory concentration: > 100000 nM
Compound 3 ended at the assay's limit (the forecaster's own chance of this, stated with the estimate: 85%); the middle value lies on the limit itself.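

For the compounds shown here, compound 1 and compound 3 both stand at a limit of this assay and not at a number, so the exchange of methyl for methylsulfanyl between them gives no step that can be read. The compounds shown leave open which change to the shared core, if any, would give a numeric value in this assay.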